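Working notes: bromo for nitro, compound 2 to compound 3

The source may hold more compounds than are shown below. What is called first, only, known or untested is meant among the compounds shown, and "the series" means these compounds.

compound 1 `O=C1NC(=O)/C(=C/c2ccc(OCCSc3nnc(Cc4ccccc4)[nH]3)cc2)S1`: 19.4%
compound 2 `O=C1NC(=O)/C(=C/c2ccc(OCCSc3nnc(-c4ccc([N+](=O)[O-])cc4)[nH]3)cc2)S1`: 13.9%

For the measured compounds named here, in a functional assay on the whole organism (plasma, strain Wistar) with Rattus norvegicus as the target, with a stated time of 15 days, at a dose of 10 mg/kg by the oral route (a higher number here means a stronger effect of the compound at the dose given, a lower number a weaker effect), compound 2 gives 13.9%, within the scatter of compound 1, which gives 19.4%; the only measured step, a number 5.5 percentage points lower from compound 1 to compound 2 (within the scatter), is therefore without weight. Compound 3 `O=C1NC(=O)/C(=C/c2ccc(OCCSc3nnc(-c4ccc(Br)cc4)[nH]3)cc2)S1` differs from compound 2 by bromo in place of nitro on an aromatic carbon. Going by the values given here, no measured step concerns a bromo for nitro exchange, and the one step known is within the scatter, so no step beyond the scatter is expected in this assay. The expected step is a number 1.1 percentage points higher from compound 2 to compound 3 (within the scatter). Compound 3 is estimated at 15%, with a range from 5% to 26%.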

Compound 3, a percentage reported as activity, at one dose (the size of the read-out at that dose, not a potency): 20.4%
Compound 3: the middle estimate sits 5.4 percentage points below what was measured; the range from low to high includes it.
By their numbers in this assay, from the lowest: compounds 2, 1 and 3 (each within the scatter of the next).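

In this assay, bromo in place of nitro gives a number 6.5 percentage points higher from compound 2 to compound 3 (within the scatter), and 4-bromophenyl in place of benzyl gives a number 1 percentage points higher from compound 1 to compound 3 (within the scatter). Benzyl, 4-nitrophenyl and 4-bromophenyl on this aromatic carbon of the shared core therefore all lie within the scatter of one another, and neither change separates the compounds. No supporting evidence accompanies these numbers. From the compounds shown here alone, whether an amine or a carboxylic acid in place of bromo, or a longer chain in place of benzyl, would give a step beyond the scatter stays open.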